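This account rests on a few compounds, and the source may have more. Where it says the series, first, only, none or still open, it means among the compounds named here.

Working notes on the series, which shares one core across three measured compounds and one still to be measured.

Compound 1 `O=C1/C(=C/c2cccc(Br)c2)Cc2ccccc21` gives 21000 nM in a functional assay on P388 cells (Mus musculus) for inhibition; on this read-out higher numbers stand for weaker inhibition and lower numbers for stronger inhibition. Compound 3 `Cc1cccc(/C=C2\Cc3ccccc3C2=O)c1` gives 24900 nM in this assay. The two differ by methyl in place of bromo on an aromatic carbon, and the measured step is a 1.2-fold higher number from compound 1 to compound 3 (0.07 log units; within the scatter).

Compound 2 `O=C1/C(=C/c2ccc(Br)cc2)Cc2ccccc21` has the same atoms as compound 1, joined differently; the difference between the two cores is not broken down here. In this assay compound 2 gives only a limit of the assay, > 50000 nM, not a number.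

Compound 4 `Cc1ccc(/C=C2\Cc3ccccc3C2=O)cc1` is not yet measured in this assay. From compound 2 it differs by methyl in place of bromo on an aromatic carbon. This is the same kind of change as that from compound 1 to compound 3, though the place is not the same: para to a large group here, meta to a large group there.

Since compound 2 sits at the limit of > 50000 nM in this assay, at which 1 of the 3 values shown sits, and the measured step of a 1.2-fold higher number from compound 1 to compound 3 (0.07 log units; within the scatter) lies within the scatter, the expected step is a step that the limit leaves unreadable from compound 2 to compound 4. Compound 4 is estimated at 60000 nM, within a range from 25000 nM to 150000 nM, and a limit rather than a number is quite possible.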

Compound 4, half-maximal inhibitory concentration: 38600 nM
For compound 4 the middle estimate is 1.6-fold (0.19 log units) above the measured one, within the range that was stated.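

Methyl in place of bromo on an aromatic carbon now has a reading on both cores in this assay, and the new step is an at least 1.2-fold lower number from compound 2 to compound 4 (0.11 log units; that floor lies within the scatter). Set beside the earlier step, the comparison stands as follows: the same change on two cores in this assay, a 1.2-fold higher number (0.07 log units; within the scatter) from compound 1 to compound 3 and an at least 1.2-fold lower number (0.11 log units; that floor lies within the scatter) from compound 2 to compound 4; the limit leaves it open whether they differ. Compound 2 carries a limit of the assay, > 50000 nM, not a number, so the series neither shows that this change carries over unchanged from one core to the other nor shows that it does not: the limit of > 50000 nM in this assay, at which 1 of the 4 values shown sits.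

The compounds shown leave open how the read-out in this assay responds on either core to a group other than bromo or methyl, such as an amine or a carboxylic acid. Also open, from the compounds shown here alone, is the true size of the change on the core of compound 2, which only a number in place of the limit could settle.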